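The source may report more compounds than this note shows. Statements on the series, on what has been measured and on what is new or still open speak of the compounds shown alone.

Measured compounds:
- compound 1, `CCCSc1nc(N/N=C(\C)c2ccccc2O)c2nnn(Cc3ccccc3Cl)c2n1`: > 64000 nM in a functional assay on MCF7 cells (Homo sapiens) for antiproliferative activity, read by MTT assay, with a stated time of 72 h; on this read-out lower numbers stand for stronger inhibition and higher numbers for weaker inhibition — a limit of the assay, not a number
- compound 2, `CCCSc1nc(N/N=C/c2ccc(C)cc2)c2nnn(Cc3ccccc3)c2n1`: > 64000 nM in this assay — likewise a limit
- compound 3, `CCCSc1nc(N/N=C/c2ccc(N(C)C)cc2)c2nnn(Cc3ccccc3)c2n1`: 12200 nM in this assay

Compound 2 stands at the assay limit: its value is a limit, not a number, and the same is true of compound 1, as the limit of > 64000 nM in this assay, at which 2 of the 3 values shown sit, records. Only compound 3 gives an actual number. Going by the values given here, the single measured step that can be compared is an at least 5.2-fold lower number from compound 2 to compound 3 (0.71 log units; beyond the scatter), which shows that changing the group on the aromatic ring of the hydrazone portion from methyl to dimethylamino moved the compound from the limit to a measurable value.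

The step to compound 4, `CCCSc1nc(N/N=C(\C)c2ccc(O)cc2)c2nnn(Cc3ccccc3)c2n1`, is a group of 10 heavy atoms (8 carbon, 1 nitrogen, 1 oxygen; one six-membered aromatic ring of carbon only) in place of a group of 9 heavy atoms (8 carbon, 1 nitrogen; one six-membered aromatic ring of carbon only), on a nitrogen on an aromatic ring. As for compound 3, the methyl on the aromatic ring is replaced by a group able to donate and accept hydrogen bonds, though here the extra methyl on the double bond also enters. Among the compounds with values here, the one comparable step, an at least 5.2-fold lower number from compound 2 to compound 3 (0.71 log units; beyond the scatter), was at least modest and toward stronger inhibition, so a step in the same direction is expected, but weaker, since the hydroxy-bearing compound 1 also sits at the limit.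

For compound 4 the estimate is 40000 nM, between 12000 nM and 130000 nM, meaning an expected step of an at least 1.6-fold lower number from compound 2 to compound 4 (0.20 log units; that floor lies within the scatter).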

Compound 4, half-maximal inhibitory concentration: 21600 nM
The estimate for compound 4 lay 1.9-fold (0.27 log units) above the measured number, within the range that was stated.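

In this assay, replacing the group on the nitrogen with one that carries a hydroxy group and an extra methyl on the double bond gives an at least 2.9-fold lower number from compound 2 to compound 4 (0.47 log units; beyond the scatter). Together with the dimethylamino group of compound 3, this makes a second change at this place that gives a measurable value, so a measurable value here does not depend on the dimethylamino group alone, and the group entering in compound 4 holds oxygen and a hydrogen-bond donor. On these data alone, the true size of the step remains unknown, because compound 2 has only a limit of the assay and not a number: the limit of > 64000 nM in this assay, at which 2 of the 4 values shown sit.

The step from compound 2 to compound 4 changes the hydroxy group and the extra methyl together, so these compounds cannot show which of the two matters, or whether either matters alone. As far as these compounds go, it also remains open how a methoxy group, a plain amine or a carboxylic acid on the same aromatic ring would read out, and whether a longer chain on the sulfur of the shared core would shift these values.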